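A Shorter Amine Tail on a Shared Core

The compounds below may be only part of what the source reports. "The series", "measured", "known", "first", "only" and "open" are said of these compounds alone.

This study measures cytotoxicity in a functional assay on HCT-116 cells (Homo sapiens) for cytotoxicity, read by MTT assay, with a stated time of 2 days, tested at 10 uM; on this read-out lower numbers stand for less inhibition and higher numbers for more inhibition at the one concentration tested (going by the name of the read-out). Compound 1 `CCCCNc1nc(NCc2ccco2)c2cccc(F)c2n1` is recorded as "not determined" (no result reported) in this assay, so no number exists for it. Compound 2 `c1coc(CNc2nc(NCCCN3CCCC3)nc3ccccc23)c1` gives 67.5% in this assay, and compound 3 `CCCCNc1nc(NCc2ccco2)c2cc(F)ccc2n1` gives 87.8% in this assay. Of the two numbers that exist, compound 2 stands lowest, and compound 3 lies above it by more than the usual scatter. The two compounds differ in several places at once, so the gap between them cannot be tied to any single change; only the two values themselves are known.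

Compound 4 `CCN(CC)CCNc1nc(NCc2ccco2)c2ccccc2n1` has not yet been measured in this assay. Against compound 2 the difference is diethylamino in place of (pyrrolidin-1-yl)methyl on a saturated chain carbon, two bonds along the chain from a nitrogen on an aromatic ring. Counted one bond further out, the same difference reads 3-(pyrrolidin-1-yl)propyl to 2-(diethylamino)ethyl: the chain grows one carbon shorter and the five-membered non-aromatic ring is opened, while the tail still carries one hydrogen-bond acceptor, no donor and no net charge.

Because compound 2 gives 67.5% and the change keeps that kind of amine tail, the step from compound 2 to compound 4 is expected to be small, a number 7.5 percentage points lower from compound 2 to compound 4 (within the scatter), in no clear direction beyond the scatter. Compound 4 is therefore estimated at 60%, within a range from 35% to 85%.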

Compound 4, a percentage reported as inhibition, at one concentration (the size of the read-out at that concentration, not a potency): 50.3%
The estimate for compound 4 lay 9.7 percentage points above the measured number; the measured number falls inside the stated range.
By their numbers in this assay, from the lowest: compound 4; then compound 2; then compound 3.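

Within this assay, the amine tail on the shared core proves to matter: putting diethylamino in place of (pyrrolidin-1-yl)methyl on a saturated chain carbon, two bonds along the chain from a nitrogen on an aromatic ring, gives a number 17.2 percentage points lower from compound 2 to compound 4 (beyond the scatter). Among these compounds, this is the first pair in the set that differs in one place, so the size of a change at this position can now be read directly, which the several differences separating the earlier compounds did not allow. Both departing and entering groups count 0 hydrogen-bond donors, 1 hydrogen-bond acceptor and no net charge, so these counts do not separate the two tails, and no measurement shown explains the step.

The change shortens the chain and opens the five-membered ring together, so the compounds shown cannot say how much of the step belongs to either part. A 2-(pyrrolidin-1-yl)ethyl tail, which keeps the ring on the shorter chain, or a 3-(diethylamino)propyl tail, which keeps the longer chain without the ring, would pull the two parts apart on the same core.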